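From 4-Chlorophenyl to Methoxy on a Carbonyl Carbon

This account rests on a few compounds, and the source may have more. Where it says the series, first, only, none or still open, it means among the compounds named here.

Compound 1 `CC1(C)S[C@@H]2/C(=C\C(=O)c3cc(C(F)(F)F)cc(C(F)(F)F)c3)C(=O)N2[C@H]1C(=O)OC(c1ccccc1)c1ccccc1` gives 39200 nM in a functional assay on A-375 cells (Homo sapiens) for cytotoxicity, read by MTT assay, with a stated time of 48 h; a higher number here means a weaker inhibitor, a lower number a stronger inhibitor.
Compound 2 `CC1(C)S[C@@H]2/C(=C\C(=O)c3ccc(Cl)cc3)C(=O)N2[C@H]1C(=O)OC(c1ccccc1)c1ccccc1` gives 48600 nM in this assay.
Compound 3 `CC1(C)S[C@@H]2/C(=C\C(=O)OC(c3ccccc3)c3ccccc3)C(=O)N2[C@H]1C(=O)OC(c1ccccc1)c1ccccc1` gives 9100 nM in this assay.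

Among these three, compound 2 has the highest number in this assay. Compound 1 sits so close to it that the two cannot be told apart, the gap lying within the usual scatter. Compound 3, which carries a diphenylmethoxy group in place of the 4-chlorophenyl of compound 2, has a clearly lower number, and that gap lies beyond the scatter.

Compound 4 `COC(=O)/C=C1/C(=O)N2[C@@H]1SC(C)(C)[C@@H]2C(=O)OC(c1ccccc1)c1ccccc1` has not yet been measured. It differs from compound 2 in one place: methoxy in place of 4-chlorophenyl on a carbonyl carbon. For the measured compounds named here, no measured pair shows this exact exchange, so the expected size of the step is uncertain. Compound 3, with its own ester on the same carbonyl carbon, does give a lower number, which hints that an ester here may be tolerated or favoured. The step of a 1.9-fold lower number from compound 2 to compound 4 (0.29 log units; within the scatter) is therefore estimated to run toward a lower number, of modest size, possibly within the scatter. Compound 4 is expected to give about 25000 nM in this assay, within a range from 8000 nM to 70000 nM.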

Compound 4, half-maximal inhibitory concentration: 24600 nM
The estimate for compound 4 lay 1.0-fold (0.01 log units) above the measured number, and the stated range covers the measured number.
By their numbers in this assay, from the lowest: compound 3; then compounds 4, 1 and 2 (each within the scatter of the next).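

On this carbonyl carbon, whose other neighbour is the double-bonded chain carbon, exchanging 4-chlorophenyl for methoxy in this assay gives a 2.0-fold lower number from compound 2 to compound 4 (0.30 log units; within the scatter) and so cannot be told apart from no change at all. This is a large change in structure: a group of 7 heavy atoms with one six-membered aromatic ring leaves, and a group of 2 heavy atoms with no ring and 1 hydrogen-bond acceptor enters, yet the two compounds read alike, so compound 2 does not need its aromatic ring here to keep this level of cytotoxicity. Nothing shown explains why the number holds across this exchange.

Among the two esters on this carbon, compound 3, with diphenylmethoxy, gives 9100 nM and compound 4, with methoxy, gives 24600 nM in this assay but the compounds shown do not say what the number does with an ester chain of intermediate length, such as ethoxy or benzyloxy. As far as these compounds go, it also remains open how a carboxylic acid, or an amide formed from an amine, would read on this same carbonyl carbon.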